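A few compounds are considered here, and "the series" means these few. Any claim that something is new, unique, unknown or untested is made for them only; others in the source may bear on it.

Measured so far:
Compound 1 `Cc1nc(C)c(Cn2ncc3c(Nc4ccc(OC(F)(F)F)cc4)ncnc32)s1` — > 10000 nM
Compound 2 `NC(=O)c1cccc(Nc2cc(Nc3ccc(OC(F)(F)F)cc3)ncn2)c1` — > 10000 nM
Compound 3 `FC(F)(F)Oc1ccc(Nc2ncnc3nn(Cc4cccnc4)cc23)cc1` — > 10000 nM

In an ADME assay on BaF3 cells (Mus musculus) for cytotoxicity (on this read-out higher numbers stand for an effect only at larger amounts of compound and lower numbers for an effect already at smaller amounts), compound 1 gives > 10000 nM, which is a limit of the assay and not a number. Compound 2 likewise gives only a limit, > 10000 nM. Compound 3 also gives a limit, > 10000 nM. The shared picture is summed up as the limit of > 10000 nM in this assay, at which 3 of the 3 values shown sit. For the measured compounds named here, no step between two measured compounds is known here, so the three values show only that each sits at the same limit; nothing beyond that can be read from them.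

Compound 4 `FC(F)(F)Oc1ccc(Nc2ncnc3c2cnn3CC2CCOC2)cc1` is the compound still to be measured. It differs from compound 1 in one place: oxolan-3-yl in place of 2,4-dimethyl-1,3-thiazol-5-yl on a saturated chain carbon bound to an aromatic nitrogen. With compound 1 at the limit, the step from compound 1 to compound 4 is expected to be none beyond the usual scatter, so that a step that the limit leaves unreadable from compound 1 to compound 4 is the expected change. Compound 4 is therefore expected to give about 20000 nM in this assay, within a range from 8000 nM to 60000 nM, most likely again as a limit.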

Compound 4, half-maximal effective concentration: > 10000 nM
Compound 4 gave a limit, no number; the forecaster's own chance of this, stated with the estimate: 85%; the middle value lies beyond the limit too.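

In this assay, for the compounds shown here, compound 1 and compound 4 each give only a limit, so no step between them can be read. The compounds shown leave open at what amount any of them would show an effect in this assay and whether oxolan-3-yl in place of 2,4-dimethyl-1,3-thiazol-5-yl changes that amount.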